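The source may report more compounds than this note shows. Statements on the series, on what has been measured and on what is new or still open speak of the compounds shown alone.

In a functional assay on HeLa cells (Homo sapiens) for inhibition, read by sulforhodamine B assay (on this read-out lower numbers stand for stronger inhibition and higher numbers for weaker inhibition), compound 1 `Cc1ccc(NC2=CC(=O)c3c(nc4n3[C@H]3OC[C@@H](O)[C@H]3OC4)C2=O)cc1C` gives 4320 nM. Compound 2 `CCOc1ccc(NC2=CC(=O)c3nc4n(c3C2=O)[C@H]2OC[C@@H](O)[C@H]2OC4)cc1`, measured in this assay, gives 3110 nM. These two numbers lie within the usual scatter of each other, so compound 1 stands level with compound 2 rather than apart from it. Compound 3 `COc1cccc(NC2=CC(=O)c3c(nc4n3[C@H]3OC[C@@H](O)[C@H]3OC4)C2=O)c1` differs from compound 1 in one place: 3-methoxyphenyl in place of 3,4-dimethylphenyl on an amine nitrogen. For the measured compounds named here, no measured pair shows this change, so only a small step is expected from compound 1 to compound 3, of a size a 1.0-fold higher number from compound 1 to compound 3 (0.02 log units; within the scatter), in no clear direction. Compound 3 is expected to give about 4500 nM in this assay, within a range from 1500 nM to 13000 nM.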

Compound 3, half-maximal inhibitory concentration: > 8000 nM
Compound 3 gave a limit, no number; the forecaster's own chance of this, stated with the estimate: 10%; at least 1.7-fold (0.24 log units) between middle value and limit.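

In this assay compound 3 gives a limit of the assay, not a number: the limit of > 8000 nM in this assay, at which 1 of the 3 values shown sits. Placing 3-methoxyphenyl in place of 3,4-dimethylphenyl on the amine nitrogen gives an at least 1.8-fold higher number from compound 1 to compound 3 (0.26 log units; that floor lies within the scatter), so only a floor for this step can be read, and its true size remains unknown. Even so, this pair isolates a single change at this position, and the swap brings no sign of stronger inhibition.

On these data alone, whether compound 3 truly differs from compound 1 stays open. Also open, as far as these compounds go, is how a pyridyl ring or a longer alkyl chain on that nitrogen would read in this assay.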